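A few compounds are considered here, and "the series" means these few. Any claim that something is new, unique, unknown or untested is made for them only; others in the source may bear on it.

In a functional assay on CCRF-CEM cells (Homo sapiens) for inhibition, read by sulforhodamine B assay, with a stated time of 48 h (a lower number here means a stronger inhibitor of growth, a higher number a weaker inhibitor of growth), compound 1 (`O=C(Cc1csc2nc(-c3ccc(Br)cc3)cn12)N/N=C/c1ccccc1`) gives 17400 nM. Among the compounds with values here, compound 2 (`O=C(Cc1csc2nc(-c3ccc(Br)cc3)cn12)N/N=C/c1ccccc1O`) gives 1820 nM, the lower of the two numbers measured so far, which makes it the stronger inhibitor of growth of the pair. Next comes compound 3 (`O=C(Cc1csc2nc(-c3ccc(Br)cc3)cn12)N/N=C/c1ccc(O)cc1`), which has the same atoms as compound 2, joined differently: 4-hydroxyphenyl in place of 2-hydroxyphenyl on a carbon with a double bond to nitrogen. The change is 4-hydroxyphenyl in place of 2-hydroxyphenyl on a carbon with a double bond to nitrogen.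

Within the data shown here, only one measured step bears on this change: a 9.6-fold lower number from compound 1 to compound 2 (0.98 log units; beyond the scatter), a modest step beyond the scatter, with hydroxy in place of hydrogen on an aromatic carbon. Among the measured compounds shown here, no measured compound carries 4-hydroxyphenyl, so the data do not show whether that gain carries over to the new arrangement. Part of it is expected to be lost, leaving the number for compound 3 somewhere in the span set by the two measured compounds. The expected change is a 2.2-fold higher number from compound 2 to compound 3 (0.34 log units; beyond the scatter), a modest rise. In this assay the estimate for compound 3 is 4000 nM, with an expected range of 1200 nM to 14000 nM.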

Compound 3, concentration for 50% growth inhibition: 12300 nM
The estimate for compound 3 lay 3.1-fold (0.49 log units) below the measured number; low and high end bracket the measured number.
By their numbers in this assay, from the lowest: compound 2; then compounds 3 and 1 (each within the scatter of the next).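

In this assay, the gain from the hydroxy group turns out to depend on its arrangement: 4-hydroxyphenyl in place of 2-hydroxyphenyl on the carbon with a double bond to nitrogen gives a 6.8-fold higher number from compound 2 to compound 3 (0.83 log units; beyond the scatter), which gives back most of the earlier gain of a 9.6-fold lower number from compound 1 to compound 2 (0.98 log units; beyond the scatter). Against compound 1, which carries no hydroxy on this ring, the 4-hydroxyphenyl arrangement gives a 1.4-fold lower number from compound 1 to compound 3 (0.15 log units; within the scatter), so among these three compounds only the 2-hydroxyphenyl arrangement separates from the parent by more than the scatter. Nothing given here explains why the two arrangements with the same atoms behave so differently.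

Going by these compounds, it remains open whether a methoxy group, an amine or a fluorine in place of the hydroxy of compound 2 would keep the lower number, or whether the gain is particular to hydroxy. On these data alone, it is equally open whether the difference between 2-hydroxyphenyl and 4-hydroxyphenyl would persist if a chlorine or a methyl group replaced the bromine on the shared core.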